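Swapping furan for thiophene on a growth-inhibiting compound

The source may report more compounds than this note shows. Statements on the series, on what has been measured and on what is new or still open speak of the compounds shown alone.

- Compound 1 `O=C1NCCC12CCN(c1c(Cl)cncc1-c1ccco1)CC2`: 940 nM
- Compound 2 `O=C1NCCC12CCN(c1c(Cl)cncc1-c1ccoc1)CC2`: 750 nM

In a functional assay on MV4-11 cells (Homo sapiens) for inhibition, read by resazurin assay, with a stated time of 72 h (on this read-out lower numbers stand for stronger inhibition of growth and higher numbers for weaker inhibition of growth), compound 1 gives 940 nM. For the measured compounds named here, only one other number exists for comparison, and it lies close by, so compound 1 sits level with its single measured neighbour. Going by the values given here, the one measured step is a 1.3-fold lower number from compound 1 to compound 2 (0.10 log units; within the scatter).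

Compound 3 `O=C1NCCC12CCN(c1c(Cl)cncc1-c1cccs1)CC2` has not yet been measured. It keeps the core of compound 1 and has thiophen-2-yl in place of furan-2-yl on an aromatic carbon.

The measured step bears on this change only indirectly. Among the compounds with values here, it exchanged furan-2-yl for furan-3-yl, not for a thiophene, and no measured pair shows the new group. Within the data shown here, still, it is the only guide, and that swap of one five-membered aromatic ring for another stayed within the scatter. No step beyond the scatter is therefore expected in this assay, and no direction can be favoured with confidence. The expected step is a 1.2-fold lower number from compound 1 to compound 3 (0.07 log units; within the scatter).

Compound 3 is estimated at 800 nM, with an expected range from 350 nM to 1800 nM.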

Compound 3, concentration for 50% growth inhibition: 480 nM
Compound 3: middle estimate off by 1.7-fold (0.22 log units), on the high side; the measured number falls inside the stated range.
By their numbers in this assay, from the lowest: compounds 3, 2 and 1 (each within the scatter of the next).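

In this assay, the step to thiophen-2-yl on this aromatic carbon is a 2.0-fold lower number from compound 1 to compound 3 (0.29 log units; within the scatter), and the comparison with the other furan is a 1.6-fold lower number from compound 2 to compound 3 (0.19 log units; within the scatter). The earlier pair showed only that the oxygen could sit at a different place in a furan ring; these steps add that sulfur can take the place of oxygen in the ring without a change beyond the scatter. All three compounds carry a five-membered aromatic ring with one hetero atom, and on this read-out they cannot be told apart with any confidence, so the position accepts each of these three rings about equally. No measurement offered here explains the small differences among them.

These compounds leave open whether growth inhibition would hold with a ring of another size or kind at this carbon, such as phenyl or morpholine, or with a small chain such as methyl. They also leave open whether thiophen-3-yl would fall within the same scatter, and whether the chloro group on the same ring could be replaced by a methoxy group.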